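Solubility notes: aryl swap on the benzyl arm

The source may report more compounds than this note shows. Statements on the series, on what has been measured and on what is new or still open speak of the compounds shown alone.

Measured compounds:
compound 1 `COc1cccc(CNCCCNc2ccnc3cc(Cc4cccc(C(F)(F)F)c4)ccc23)c1O` gives 4200 nM in a physicochemical assay for solubility, with a stated time of 18 h, at pH 7.4; a higher number here means a more soluble compound, a lower number a less soluble compound.
compound 2 `COc1ccc(F)cc1CNCCCNc1ccnc2cc(Cc3cccc(C(F)(F)F)c3)ccc12` gives 4200 nM in this assay.
compound 3 `FC(F)(F)c1cccc(Cc2ccc3c(NCCCNCc4ccco4)ccnc3c2)c1` gives 4200 nM in this assay.

Compound 1 stands level with compounds 2 and 3 at the digits shown. The three measured steps all sit on the saturated chain carbon bound to an amine nitrogen: no change at the digits printed from compound 1 to compound 2 (within the scatter), no change at the digits printed from compound 1 to compound 3 (within the scatter) and no change at the digits printed from compound 2 to compound 3 (within the scatter), each within the scatter. Three different groups at that end of the chain leave the read-out unmoved.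

Compound 4 `COc1cccc(CNCCCNc2ccnc3cc(Cc4ccc(F)cc4Cl)ccc23)c1O` is the next compound. (2-chloro-4-fluorophenyl in place of 3-(trifluoromethyl)phenyl on a saturated chain carbon bound to an aromatic carbon). Going by the values given here, this change sits on a saturated chain carbon bound to an aromatic carbon, a position no measured step touches, so none of the three steps bears on it directly. What the data do show is that the read-out of compounds 1, 2 and 3 did not move under any change tried so far, and the swap here keeps the same count of donors and acceptors and no net charge. The expected step of no change at the digits printed from compound 1 to compound 4 (within the scatter) is therefore none beyond the scatter. Compound 4 is estimated at 4200 nM in this assay, with an expected range from 2000 nM to 8500 nM.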

Compound 4, solubility: 4200 nM
Compound 4: middle estimate and measured number agree at the digits printed; low and high end bracket the measured number.
By their numbers in this assay, from the lowest: compounds 1, 2, 3 and 4 (each within the scatter of the next).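

Going by these compounds alone, the step on a saturated chain carbon bound to an aromatic carbon gives the first reading at this second position in this assay: with 2-chloro-4-fluorophenyl in place of 3-(trifluoromethyl)phenyl, the series shows no change at the digits printed from compound 1 to compound 4 (within the scatter). Until now, only the groups on a saturated chain carbon bound to an amine nitrogen had been varied, so the flat read-out now extends to a change at a different place in the molecule, one that takes the group from 10 heavy atoms to 8 and exchanges three fluorines for one fluorine and one chlorine, with hydrogen-bond donors and acceptors at 0 on both sides. No supporting measurement is available to explain this result.

As far as these compounds go, this position rests on a single pair, and both of its aryl groups carry only halogen or trifluoromethyl substituents, so the effect of a dimethylamino group or a carboxylic acid on that ring remains open. Also open, from the compounds shown here alone, is whether 2-chloro-4-fluorophenyl would give the same read-out with the furan-2-yl or 5-fluoro-2-methoxyphenyl group at the other end of the chain, or whether a longer chain would shift it.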